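Three Amines Level, a Fourth Awaits Measurement

A few compounds are considered here, and "the series" means these few. Any claim that something is new, unique, unknown or untested is made for them only; others in the source may bear on it.

Measured in a functional assay on HCT-15 cells (Homo sapiens) for inhibition, read by MTT assay, with a stated time of 72 h; on this read-out lower numbers stand for stronger inhibition and higher numbers for weaker inhibition:
- compound 1 `CCN1CCN(Cc2c(OC)cc(Oc3cccc(Nc4ccccc4)c3)cc2OC)CC1` gives 5090 nM
- compound 2 `COc1cc(Oc2cccc(Nc3ccccc3)c2)cc(OC)c1CNCc1ccc(Br)cc1` gives 5410 nM
- compound 3 `COc1cc(Oc2cccc(Nc3ccccc3)c2)cc(OC)c1CNCCNC(C)=O` gives 5090 nM

Compound 1 stands at the same number as compound 3, and the step of no change at the digits printed from compound 1 to compound 3 (within the scatter) is within the scatter. Toward compound 2 the step of a 1.1-fold higher number from compound 1 to compound 2 (0.03 log units; within the scatter) is also within the scatter, so on the numbers shown the three compounds cannot be told apart.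

Compound 4 `COc1cc(Oc2cccc(Nc3ccccc3)c2)cc(OC)c1CNC(C)C` is the next variation on the same core. Its difference from compound 1 is isopropylamino in place of 4-ethylpiperazin-1-yl on a saturated chain carbon bound to an aromatic carbon. The two measured steps that bear on this are the ones that exchange the same group at the same place: a 1.1-fold higher number from compound 1 to compound 2 (0.03 log units; within the scatter) and no change at the digits printed from compound 1 to compound 3 (within the scatter). Both stay within the scatter, so two quite different amines at this position left the number unchanged.

The step to compound 4 is therefore expected to be a 1.0-fold higher number from compound 1 to compound 4 (0.01 log units; within the scatter), with no change beyond the scatter in this assay. Compound 4 is estimated at 5200 nM, within a range from 2600 nM to 10400 nM.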

Compound 4, half-maximal inhibitory concentration: > 20000 nM
Compound 4: no number, only a limit; the forecaster's own chance of this, stated with the estimate: 3%; at least 3.8-fold (0.58 log units) between middle value and limit.
By their numbers in this assay, from the lowest: compounds 1, 3 and 2 (each within the scatter of the next). At a limit, above all of these: compound 4.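

The position is less forgiving than the three level compounds suggested: in this assay, the change to isopropylamino gives an at least 3.9-fold higher number from compound 1 to compound 4 (0.59 log units; beyond the scatter), and the comparisons with the other two amines give an at least 3.9-fold higher number from compound 3 to compound 4 (0.59 log units; beyond the scatter) and an at least 3.6-fold higher number from compound 2 to compound 4 (0.56 log units; beyond the scatter). Losing the ring of 4-ethylpiperazin-1-yl cannot be enough on its own to produce this, since the (2-acetamidoethyl)amino group of compound 3 has no ring and still stands level with compound 1. The reading for compound 4 is a limit and not a number, so these steps set only a minimum size: the limit of > 20000 nM in this assay, at which 1 of the 4 values shown sits.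

From the compounds shown here alone, how far compound 4 lies past that limit stays open. Also open, going by these compounds, is whether the weaker result belongs to isopropylamino alone, and an ethylamino group or a longer chain such as hexylamino on the same carbon would bear on that.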